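The source may report more compounds than this note shows. Statements on the series, on what has been measured and on what is new or still open speak of the compounds shown alone.

Measured compounds:
Compound 1 `CN1CCN(CCCN(C[C@H]2Cc3ccccc3CN2)[C@H]2CCCc3cccnc32)CC1`: 360 nm/s
Compound 2 `CC(C)N1CCN(CCCN(C[C@H]2Cc3ccccc3CN2)[C@H]2CCCc3cccnc32)CC1`: 344 nm/s

In an ADME assay for permeability, using PAMPA, with a stated time of 4 h, at pH 7.4 (on this read-out lower numbers stand for lower permeability and higher numbers for higher permeability), compound 2 stands lowest of the two numbers, though its nearest neighbour, compound 1, sits within the scatter of it. Compound 3 `c1ccc2c(c1)CN[C@@H](CN(CCN1CCNCC1)[C@H]1CCCc3cccnc31)C2` has not yet been measured. The change from compound 2 to compound 3 is piperazin-1-yl in place of (4-isopropylpiperazin-1-yl)methyl on a saturated chain carbon, two bonds along the chain from an amine nitrogen.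

Among the compounds with values here, the one measured step, a 1.0-fold lower number from compound 1 to compound 2 (0.02 log units; within the scatter), changed only the alkyl group on the ring nitrogen and made no difference beyond the scatter. Within the data shown here, that step does not test a change of the kind from compound 2 to compound 3, in which part of the chain and the isopropyl group leave together, so no measured step bears directly on it. With no guide from the data, a modest fall is expected rather than a large one. For compound 3 the estimate in this assay is 150 nm/s, with a range of 60 nm/s to 350 nm/s, which would mean an expected step of a 2.3-fold lower number from compound 2 to compound 3 (0.36 log units; beyond the scatter).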

Compound 3, apparent permeability: 10 nm/s
Estimate against measurement, compound 3: 15-fold (1.18 log units) above; measured number outside the range, below it.
By their numbers in this assay, from the lowest: compound 3; then compounds 2 and 1 (each within the scatter of the next).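

In this assay this position matters far more than the alkyl group on the ring nitrogen: the change to piperazin-1-yl gives a 34-fold lower number from compound 2 to compound 3 (1.54 log units; beyond the scatter) and a 36-fold lower number from compound 1 to compound 3 (1.56 log units; beyond the scatter) in the same direction, while a 1.0-fold lower number from compound 1 to compound 2 (0.02 log units; within the scatter) stays within the scatter. The large fall therefore appears whichever of the two alkyl groups compound 3 is compared against. No measurement is at hand to explain this fall.

Compound 3 differs from the others in two ways at once, with a shorter chain and with the hydrogen-bond donor that enters, so the compounds shown cannot say which of the two goes with the fall. A 4-methylpiperazin-1-yl group on the shorter chain, or a (piperazin-1-yl)methyl group on the longer one, would separate them.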